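Swapping the five-membered ring on a coumarin-type core

The compounds below may be only part of what the source reports. "The series", "measured", "known", "first", "only" and "open" are said of these compounds alone.

Compound 1 `CCN(CC)c1ccc2cc(-c3nc(C)cs3)c(=O)oc2c1` is one of two measured members of this set. In an assay on isolated protein for inhibition of Aromatase (Homo sapiens), read by scintillation counting, using NADPH, with a stated time of 15 min (on this read-out lower numbers stand for stronger inhibition and higher numbers for weaker inhibition), compound 1 gives 1100 nM. For the measured compounds named here, its measured companion, compound 2 `CCOC(=O)c1csc(-c2cc3ccc(N(CC)CC)cc3oc2=O)n1`, in this assay gives 1100 nM, so the two stand level, and the one recorded step, no change at the digits printed from compound 1 to compound 2 (within the scatter), altered only a substituent on the 4-methyl-1,3-thiazol-2-yl group without moving the read-out.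

Compound 3 `CCN(CC)c1ccc2cc(-c3cnco3)c(=O)oc2c1` has not been measured. It differs from compound 1 by 1,3-oxazol-5-yl in place of 4-methyl-1,3-thiazol-2-yl on an aromatic carbon. Going by the values given here, no measured step exchanges the whole five-membered ring; the step of no change at the digits printed from compound 1 to compound 2 (within the scatter) bears on it only in showing that this part of the molecule tolerated a change in this assay without a shift beyond the scatter. A step of similar or slightly larger size is therefore expected, leaning toward weaker inhibition, as a 1.5-fold higher number from compound 1 to compound 3 (0.16 log units; within the scatter). Compound 3 is estimated in this assay at 1600 nM, within a range from 500 nM to 5000 nM.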

Compound 3, half-maximal inhibitory concentration: 3100 nM
Compound 3: middle estimate off by 1.9-fold (0.29 log units), on the low side; measured number inside the range.
By their numbers in this assay, from the lowest: compounds 1 and 2 (each within the scatter of the next); then compound 3.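

Where the earlier step, no change at the digits printed from compound 1 to compound 2 (within the scatter), changed only a substituent on the 4-methyl-1,3-thiazol-2-yl group, exchanging the whole group does move the read-out. In this assay, 1,3-oxazol-5-yl in place of 4-methyl-1,3-thiazol-2-yl gives a 2.8-fold higher number from compound 1 to compound 3 (0.45 log units; beyond the scatter), a modest weakening that goes beyond the scatter, so this aromatic carbon of the shared core is sensitive to which five-membered ring it carries. Nothing measured on these compounds accounts for the shift.

This exchange alters the ring and removes the methyl together, so the compounds shown leave open which of these carries the step, and whether an unsubstituted 1,3-thiazol-2-yl would stand with compound 1 or with compound 3. Also open, going by these compounds, is whether an amine or a carboxylic acid on the five-membered ring would shift the number.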